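The compounds below may be only part of what the source reports. "The series", "measured", "known", "first", "only" and "open" are said of these compounds alone.

In an ADME assay on LLC-MK2 cells (Macaca mulatta) for cytotoxicity, read by spectrophotometry and crystal violet staining, with a stated time of 4 days (a lower number here means that less compound is tolerated, a higher number that more compound is tolerated), two compounds have been measured so far. Compound 1 (`CC(C)n1ncc2c(C(=O)Nc3c(F)cccc3F)cc(-c3cccs3)nc21`) reads > 200000 nM, which is a limit of the assay and not a number. Within the data shown here, compound 2 (`CC(C)n1ncc2c(C(=O)Nc3ccccc3F)cc(-c3cccs3)nc21`) gives 50000 nM, the only true number available. Putting hydrogen in place of fluoro on an aromatic carbon gives an at least 4.0-fold lower number from compound 1 to compound 2 (0.60 log units; beyond the scatter). Among the measured compounds shown here, this is the only measured step, and compound 1 stands at the limit of > 200000 nM in this assay, at which 1 of the 2 values shown sits.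

Compound 3 (`CC(C)n1ncc2c(C(=O)Nc3ccccc3S(N)(=O)=O)cc(-c3cccs3)nc21`) differs from compound 2 in a single group: sulfamoyl in place of fluoro on an aromatic carbon. In words, sulfamoyl takes the place of fluoro on an aromatic carbon, ortho to a large group, turning 2-fluorophenyl into 2-sulfamoylphenyl. For the measured compounds named here, no measured step introduces a sulfamoyl, so the loss of a fluoro seen in an at least 4.0-fold lower number from compound 1 to compound 2 (0.60 log units; beyond the scatter) offers only a loose guide: a single change on an aromatic carbon can move this number beyond the scatter. A modest rise from the 50000 nM of compound 2 is therefore expected, with low confidence in its direction. The expected change is a 1.8-fold higher number from compound 2 to compound 3 (0.26 log units; within the scatter). For compound 3, the estimated value is 90000 nM, with an expected range from 30000 nM to 200000 nM.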

Compound 3, half-maximal cytotoxic concentration: 25000 nM
Beside the measured number, compound 3's estimate is 3.6-fold (0.56 log units) above it, outside the stated range (below it).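

In this assay, among these compounds, sulfamoyl in place of fluoro gives a 2.0-fold lower number from compound 2 to compound 3 (0.30 log units; within the scatter), so at this aromatic carbon, ortho to a large group, exchanging the single fluorine for a group of four heavy atoms with a hydrogen-bond donor produces no shift beyond the scatter. Among the compounds shown here, replacing the whole aryl group, 2-sulfamoylphenyl in place of 2,6-difluorophenyl on an amide-type nitrogen, gives an at least 8.0-fold lower number from compound 1 to compound 3 (0.90 log units; beyond the scatter), and so the two steps beyond the scatter both start from the 2,6-difluorophenyl compound, while the one step between the two singly substituted rings does not. Compound 1 is a limit of the assay and not a number, and the size of each step from it is open at the upper end: the limit of > 200000 nM in this assay, at which 1 of the 3 values shown sits.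

The compounds shown leave open whether an amine, a carboxylic acid or a methyl group at this same aromatic carbon would also stay within the scatter of the 2-fluorophenyl compound. They also leave open whether a fluoro added to the 2-sulfamoylphenyl ring would raise the number as the second fluoro of compound 1 does.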